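The compounds below may be only part of what the source reports. "The series", "measured", "known", "first", "only" and "open" are said of these compounds alone.

Of the compounds shown here, three built on a shared core have been measured in a functional assay on SMMC-7721 cells (Homo sapiens) for inhibition, read by CCK-8 assay, with a stated time of 72 h, tested at 2 uM; a higher number here means more inhibition of growth at the concentration tested, a lower number less inhibition of growth. Compound 1 `CCc1ccc(SCc2ccc(C(=O)Nc3ccccc3N)cc2)cc1` gives 25.7%, compound 2 `Cc1ccc(SCc2ccc(C(=O)Nc3ccccc3N)cc2)cc1` gives 25.1%, and compound 3 `Nc1ccccc1NC(=O)c1ccc(CSCCc2ccccc2)cc1` gives 28.1%. These numbers lie within the usual scatter of one another, so compound 3 cannot be told apart from the other two.

The next structure, compound 4 `Nc1ccccc1NC(=O)c1ccc(CSc2ccc(F)cc2)cc1`, differs from compound 3 in one place: 4-fluorophenyl in place of phenethyl on a sulfur. In words, it has 4-fluorophenyl in place of phenethyl on a sulfur. Compound 4 therefore resembles compound 1 and compound 2, which carry 4-ethylphenyl and 4-methylphenyl on that sulfur.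

The most relevant evidence is the same kind of exchange seen in the opposite direction: a number 2.4 percentage points higher from compound 1 to compound 3 (within the scatter), and a number 3 percentage points higher from compound 2 to compound 3 (within the scatter). Exchanging the group on the aromatic ring also moved little, as a number 0.6 percentage points lower from compound 1 to compound 2 (within the scatter) shows. Going by the values given here, no compound measured so far carries fluorine, so that feature remains untested.

Given the small steps involving compound 1 and compound 2, no change beyond the scatter is expected, and the estimated step is a number 2.1 percentage points lower from compound 3 to compound 4 (within the scatter). For compound 4, the expected value is 26%, with an estimated range from 16% to 36%.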

Compound 4, percent growth inhibition at one concentration: 6.58%
Beside the measured number, compound 4's estimate is 19.4 percentage points above it; the measured number lies below the stated range.
By their numbers in this assay, from the lowest: compound 4; then compounds 2, 1 and 3 (each within the scatter of the next).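

In this assay, going by these compounds alone, the earlier steps gave the impression that the group on the sulfur tolerates exchange, but this result shows that one change on its aromatic ring matters: fluoro in place of methyl on an aromatic carbon gives a number 18.5 percentage points lower from compound 2 to compound 4 (beyond the scatter) and fluoro in place of ethyl on an aromatic carbon gives a number 19.1 percentage points lower from compound 1 to compound 4 (beyond the scatter) in this series. The wider exchange of 4-fluorophenyl in place of phenethyl on a sulfur gives a number 21.5 percentage points lower from compound 3 to compound 4 (beyond the scatter) and is of similar size, even though compound 1 and compound 2 also carry an aromatic ring on the sulfur and stay within the scatter of compound 3, so among these four compounds the loss goes with the fluoro group and not with having such a ring on the sulfur. No measurement available here accounts for this fall in growth inhibition.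

As far as these compounds go, it remains open whether fluoro itself lowers the number or whether the alkyl groups, methyl and ethyl, are what keep it up. Chloro, methoxy or an amine at that aromatic carbon, or a plain phenyl ring with hydrogen there, would help separate these two readings.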